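Carbamoyl for fluoro on the highest-numbered compound

A few compounds are considered here, and "the series" means these few. Any claim that something is new, unique, unknown or untested is made for them only; others in the source may bear on it.

In a functional assay on NCI-H1975 cells (Homo sapiens) for antiproliferative activity, read by CCK-8 assay, with a stated time of 72 h (a lower number here means a stronger inhibitor of growth, a higher number a weaker inhibitor of growth), compound 1 `CC[C@@H]1C(=O)N(C)c2cnc(Nc3ccc(S(=O)(=O)NC)cc3)nc2N1C1CCCC1` gives 1410 nM and compound 2 `CCCCNS(=O)(=O)c1ccc(Nc2ncc3c(n2)N(C2CCCC2)[C@H](CC)C(=O)N3C)cc1` gives 1610 nM. Compound 3 `CCC1C(=O)N(C)c2cnc(-n3ccc4cc(F)ccc43)nc2N1c1ccn(C)n1` gives 28600 nM, the highest number of the three and beyond the scatter from both others. Compound 4 `CCC1C(=O)N(C)c2cnc(-n3ccc4cc(C(N)=O)ccc43)nc2N1c1ccn(C)n1` has not yet been measured. It differs from compound 3 in one place: carbamoyl in place of fluoro on an aromatic carbon. In words, this is carbamoyl in place of fluoro on an aromatic carbon.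

For the measured compounds named here, the only measured single change, a 1.1-fold higher number from compound 1 to compound 2 (0.06 log units; within the scatter), concerns a chain on a sulfonamide nitrogen, a group that compound 3 lacks. Going by the values given here, it therefore says nothing direct about this swap, and no measured step shows what carbamoyl does here. Compound 3 stands so high, at 28600 nM, that a lower number seems somewhat more likely than a higher one, though only tentatively. The expected size is modest, and the estimate is a 1.8-fold lower number from compound 3 to compound 4 (0.25 log units; within the scatter). For compound 4 the estimated value is 16000 nM, with an expected range of 3500 nM to 50000 nM.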

Compound 4, concentration for 50% growth inhibition: "not active" (no number reported)
Compound 4: no number reported, so the estimate cannot be set against anything.
By their numbers in this assay, from the lowest: compounds 1 and 2 (each within the scatter of the next); then compound 3.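

In this assay, for the compounds shown here, compound 4 is reported as "not active" with no number, so no step from compound 3 to compound 4 can be read. The compounds shown leave open how large the effect of carbamoyl in place of fluoro is, and no other measurement bears on this result.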